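From propargyloxy to butoxy on a shared core

The compounds below may be only part of what the source reports. "The series", "measured", "known", "first", "only" and "open" are said of these compounds alone.

Three compounds sharing one core have been measured in a functional assay on aorta (Rattus norvegicus, strain Sprague-Dawley) for inhibition; a higher number here means that more compound is needed for the effect, a lower number that less compound is needed:

Compound 1 `CCCOc1cc2c(c3c1C[C@@H]1[C@@H](C)CO[C@]1(C)O3)C[C@@H]1[C@@H](C)CO[C@]1(C)O2`: 43000 nM
Compound 2 `C#CCOc1cc2c(c3c1C[C@@H]1[C@@H](C)CO[C@]1(C)O3)C[C@@H]1[C@@H](C)CO[C@]1(C)O2`: 23000 nM
Compound 3 `COc1cc2c(c3c1C[C@@H]1[C@@H](C)CO[C@]1(C)O3)C[C@@H]1[C@@H](C)CO[C@]1(C)O2`: 17000 nM

Compound 2 stands within the scatter of both other compounds, with a 1.9-fold lower number from compound 1 to compound 2 (0.27 log units; within the scatter) on one side and a 1.4-fold lower number from compound 2 to compound 3 (0.13 log units; within the scatter) on the other. Only a 2.5-fold lower number from compound 1 to compound 3 (0.40 log units; beyond the scatter) lies beyond the scatter, and it is modest.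

Compound 4 `CCCCOc1cc2c(c3c1C[C@@H]1[C@@H](C)CO[C@]1(C)O3)C[C@@H]1[C@@H](C)CO[C@]1(C)O2` has not yet been measured. Its difference from compound 2 is propyl in place of ethynyl on a saturated chain carbon bound to an oxygen on an aromatic ring, or propargyloxy to butoxy. For the measured compounds named here, no measured compound carries propyl at that carbon, so the expectation rests on the other swaps made there. The closest is ethynyl in place of ethyl, a 1.9-fold lower number from compound 1 to compound 2 (0.27 log units; within the scatter), within the scatter. Hydrogen in place of ethyl gave a 2.5-fold lower number from compound 1 to compound 3 (0.40 log units; beyond the scatter). Both lead to a lower number when ethyl leaves, so a modest move to a higher number is expected in this assay, close to the edge of the scatter. The expected change is a 2.0-fold higher number from compound 2 to compound 4 (0.29 log units; within the scatter). For compound 4 the estimated value is 45000 nM, with an expected range from 22000 nM to 90000 nM.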

Compound 4, half-maximal effective concentration: 111000 nM
Compound 4: middle estimate off by 2.5-fold (0.39 log units), on the low side, outside the stated range (above it).
By their numbers in this assay, from the lowest: compounds 3, 2 and 1 (each within the scatter of the next, the first and the last beyond it); then compound 4.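

With propyl at the saturated chain carbon bound to an oxygen on an aromatic ring, the number in this assay moves clearly away from the ethynyl compound (a 4.8-fold higher number from compound 2 to compound 4 (0.68 log units; beyond the scatter)), a separation that ethyl at this carbon did not produce. The step from hydrogen to propyl is the largest here (a 6.5-fold higher number from compound 3 to compound 4 (0.81 log units; beyond the scatter)), and adding only a methyl on a saturated chain carbon, three bonds along the chain from an oxygen on an aromatic ring, still takes the number beyond the scatter (a 2.6-fold higher number from compound 1 to compound 4 (0.41 log units; beyond the scatter)). Hydrogen, ethynyl and ethyl thus form a series in which each compound stays within the scatter of its neighbour, even though the two ends of that series lie beyond it, while compound 4 stands apart from all three as the compound needing the most for the effect.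

Nothing available here explains why the butoxy compound separates from the others. As far as these compounds go, it remains open whether a longer chain such as pentyl would raise the number further, and whether an amine or a carboxylic acid at the end of the chain would follow the same course.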